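This account rests on a few compounds, and the source may have more. Where it says the series, first, only, none or still open, it means among the compounds named here.

Compound 1, `Oc1ccc(-c2cc(-c3ccccc3F)cc(-c3ccccc3O)n2)cc1`: in a functional assay on T47D cells (Homo sapiens) for inhibition (on this read-out higher numbers stand for weaker inhibition and lower numbers for stronger inhibition), compound 1 gives > 50000 nM, a limit of the assay rather than a number.
Compound 2, `Oc1ccc(-c2cc(-c3ccccc3F)cc(-c3cccc(O)c3)n2)cc1`: in this assay compound 2 gives 6370 nM.
Compound 3, `Oc1ccccc1-c1cc(-c2ccc(OC(F)(F)F)cc2)cc(-c2ccccc2O)n1`: in this assay compound 3 gives > 50000 nM, again a limit of the assay rather than a number.

Compound 1 and compound 2 share a core and differ in one place: 3-hydroxyphenyl in place of 2-hydroxyphenyl on an aromatic carbon. That change brings an at least 7.8-fold lower number from compound 1 to compound 2 (0.89 log units; beyond the scatter); the step is only a lower bound because of the limit of > 50000 nM in this assay, at which 2 of the 3 values shown sit.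

Compound 4, `Oc1cccc(-c2cc(-c3ccc(OC(F)(F)F)cc3)cc(-c3ccccc3O)n2)c1`, has not been measured. It is related to compound 3 by a change of the same kind: 3-hydroxyphenyl in place of 2-hydroxyphenyl on an aromatic carbon. The surroundings differ, though: in compound 1 the changed group sits meta to a 2-fluorophenyl group and meta to a 4-hydroxyphenyl group, while in compound 3 it sits meta to a 2-hydroxyphenyl group and meta to a large group. The difference between the core of compound 1 and the core of compound 3 is not broken down here.

Within the data shown here, for compound 4 the expected step is an at least 3.3-fold lower number from compound 3 to compound 4 (0.52 log units; beyond the scatter), resting on the single measured change from compound 1 to compound 2, an at least 7.8-fold lower number from compound 1 to compound 2 (0.89 log units; beyond the scatter), and weakened by the different surroundings. Compound 4 is therefore estimated at 15000 nM in this assay, with an expected span from 4000 nM to 60000 nM.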

Compound 4, half-maximal inhibitory concentration: 7710 nM
For compound 4 the middle estimate is 1.9-fold (0.29 log units) above the measured one; low and high end bracket the measured number.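

In this assay, the swap of 2-hydroxyphenyl for 3-hydroxyphenyl on the second core brings an at least 6.4-fold lower number from compound 3 to compound 4 (0.81 log units; beyond the scatter), so the number falls here just as it did on the core of compound 1. The change therefore goes in the same direction on both cores, and a newly measured value now confirms this on a core carrying a 2-hydroxyphenyl group and a large group as its neighbours, though two cores are too few to promise the same on any other core, and the size of the step cannot be compared: the same change on two cores in this assay, an at least 7.8-fold lower number (0.89 log units; beyond the scatter) from compound 1 to compound 2 and an at least 6.4-fold lower number (0.81 log units; beyond the scatter) from compound 3 to compound 4; the limit leaves it open whether they differ. Going by these compounds, each step is only a lower bound, so the real gain on either core stays unknown: the limit of > 50000 nM in this assay, at which 2 of the 4 values shown sit.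

Open, on these data alone, is whether the hydroxyl itself matters or only the place it occupies, which a 3-aminophenyl or 3-methoxyphenyl group at the same spot would test. Also open, as far as these compounds go, is what happens on compound 4 if its remaining 2-hydroxyphenyl group gives way to a second 3-hydroxyphenyl group, or to a ring bearing a carboxylic acid.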